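From compound 2 to compound 3: one group exchanged

The source may hold more compounds than are shown below. What is called first, only, known or untested is meant among the compounds shown, and "the series" means these compounds.

Measured in an ADME assay on microsomes from liver (Homo sapiens) for metabolic stability, with a stated time of 10 min, tested at 0.5 uM (a lower number here means that less of the compound is left, a higher number that more of the compound is left), so far:
Compound 1 `CCC(c1nc2ncc(Cl)cc2[nH]1)[C@H]1CC[C@@H](c2ccnc3ccc(C(F)(F)F)cc32)CC1` gives 81% here
Compound 2 `CCC(c1nc2ccc(Cl)cc2[nH]1)[C@H]1CC[C@@H](c2ccnc3ccc(F)cc32)CC1` gives 82% here

Compound 2 stands level with compound 1, their two numbers lying within the usual scatter. Compound 3 `CCC(c1nc2ncc(Cl)cc2[nH]1)[C@H]1CC[C@@H](c2ccnc3ccc(F)cc32)CC1` differs from compound 2 by a group of 10 heavy atoms (6 carbon, 3 nitrogen, 1 chlorine; one five-membered aromatic ring with 2 hetero atoms, one six-membered aromatic ring with 1 hetero atom) in place of a group of 10 heavy atoms (7 carbon, 2 nitrogen, 1 chlorine; one five-membered aromatic ring with 2 hetero atoms, one six-membered aromatic ring of carbon only), on a saturated chain carbon bound to a saturated chain carbon and a saturated ring carbon and is otherwise the same. Compound 1 already carries the entering group and gives 81% in this assay though it differs from compound 3 elsewhere. For the measured compounds named here, no measured step isolates this exchange. The expected a number 1 percentage points higher from compound 2 to compound 3 (within the scatter) stays within the scatter, so no real change is anticipated. In this assay compound 3 is estimated at 83% with an expected range of 70% to 93% overall.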

Compound 3, percent of the compound remaining: 78%
Estimate against measurement, compound 3: 5 percentage points above; the range from low to high includes it.
By their numbers in this assay, from the lowest: compounds 3, 1 and 2 (each within the scatter of the next).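

In this assay, for the compounds shown here, the first direct reading of the exchange on the saturated chain carbon is a number 4 percentage points lower from compound 2 to compound 3 (within the scatter) and so shows no real change with the entering group in place of 6-chloro-1H-benzimidazol-2-yl. With that group held constant, fluoro in place of trifluoromethyl on an aromatic carbon gives a number 3 percentage points lower from compound 1 to compound 3 (within the scatter) and also shows no real change. No measurement shown accounts for either result. The compounds shown leave open how an amine or a carboxylic acid in place of fluoro on that aromatic carbon would read in this assay. They also leave open the effect of a longer chain on the saturated chain carbon.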